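Furan-2-yl Replaces Phenyl on the Shared Core

The source may hold more compounds than are shown below. What is called first, only, known or untested is meant among the compounds shown, and "the series" means these compounds.

Three measured compounds share one core and differ only in the aromatic ring attached next to the ring sulfur. Compound 1 `CC(C)(C)Cc1c(-c2ccncc2)sc(N)c1C(=O)c1ccc(Cl)cc1` carries pyridin-4-yl, compound 2 `CC(C)(C)Cc1c(-c2ccc(F)cc2)sc(N)c1C(=O)c1ccc(Cl)cc1` carries 4-fluorophenyl, and compound 3 `CC(C)(C)Cc1c(-c2ccccc2)sc(N)c1C(=O)c1ccc(Cl)cc1` carries phenyl. In an assay on CHO cells for displacement of a labelled ligand from adenosine receptor A3 (Homo sapiens), read by scintillation counting, tested at 10 uM (a higher number here means more inhibition at the concentration tested (going by the name of the read-out), a lower number less inhibition), compound 1 gives 6%, compound 2 gives 9%, and compound 3 gives 1%. Compound 3 has the lowest of the three numbers, yet every gap is small: a number 5 percentage points lower from compound 1 to compound 3 (within the scatter), a number 8 percentage points lower from compound 2 to compound 3 (within the scatter), and a number 3 percentage points higher from compound 1 to compound 2 (within the scatter). In short, none of the three compounds shows meaningful displacement of the labelled ligand at the concentration tested.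

Compound 4 `CC(C)(C)Cc1c(-c2ccco2)sc(N)c1C(=O)c1ccc(Cl)cc1` is not yet measured. Compared with compound 3, (furan-2-yl in place of phenyl on an aromatic carbon). All three measured steps bear on this change, since each alters the same ring on the same carbon of the core, and none of them moved the number beyond the scatter. Among the compounds with values here, no measured step exchanges a six-membered ring for a five-membered one, so the evidence is indirect, but it points the same way. The expected step is therefore none beyond the scatter, a number 4 percentage points higher from compound 3 to compound 4 (within the scatter). For compound 4 in this assay the estimate is 5%, expected to fall between -5% and 15%.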

Compound 4, a percentage reported as inhibition, at one concentration (the size of the read-out at that concentration, not a potency): 1%
For compound 4 the middle estimate is 4 percentage points above the measured one; measured number inside the range.
By their numbers in this assay, from the lowest: compounds 3, 4, 1 and 2 (each within the scatter of the next).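

Until now every ring at this position was six-membered, and compound 4 extends the picture to a five-membered aromatic ring with a hetero atom, on the aromatic carbon next to the ring sulfur. In this assay, replacing phenyl with furan-2-yl, which also brings a hydrogen-bond acceptor that phenyl lacks, gives no change at the digits printed from compound 3 to compound 4 (within the scatter), and the comparisons with the other two rings give a number 8 percentage points lower from compound 2 to compound 4 (within the scatter) and a number 5 percentage points lower from compound 1 to compound 4 (within the scatter), so neither ring size nor this added acceptor separates compound 4 from the other three compounds. Nothing available here offers an explanation for this flat result.

Going by these compounds, all four compounds sit so close together and so low that these rings cannot be ranked, and it remains open whether any group at this position can raise the number clearly beyond the scatter. A saturated ring such as cyclohexyl, a chain ending in an amine or a carboxylic acid, or a replacement for the neopentyl group elsewhere on the shared core would test this more sharply than another aromatic ring.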